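Methyl in place of ethoxy: notes on the series

The source may report more compounds than this note shows. Statements on the series, on what has been measured and on what is new or still open speak of the compounds shown alone.

Measured in a functional assay on XF498 cells (Homo sapiens) for cytotoxicity, read by MTT assay, with a stated time of 72 h; on this read-out higher numbers stand for weaker inhibition and lower numbers for stronger inhibition:
- compound 1 `CCOc1ccc(NC2=CC(=O)c3ncncc3C2=O)cc1`: 0.03 ug/mL
- compound 2 `O=C1C(Nc2ccc(F)cc2)=CC(=O)c2ncncc21`: 0.04 ug/mL
- compound 3 `O=C1C(Nc2ccc(I)cc2)=CC(=O)c2ncncc21`: 0.04 ug/mL

Compound 1 does not stand apart from the other two measured compounds, as all three values lie within the scatter of one another. The data show a 1.3-fold higher number from compound 1 to compound 2 (0.12 log units; within the scatter) and a 1.3-fold higher number from compound 1 to compound 3 (0.12 log units; within the scatter). Between the two halogen compounds they show no change at the digits printed from compound 2 to compound 3 (within the scatter).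

The next compound to be measured is compound 4 `Cc1ccc(NC2=CC(=O)c3ncncc3C2=O)cc1`, which has methyl in place of ethoxy on an aromatic carbon, para to a large group: methyl in place of ethoxy on an aromatic carbon. Among the measured compounds shown here, no measured compound carries methyl at this place, so the evidence is indirect. The two steps that bear on the change are the replacements of ethoxy by fluoro and by iodo, a 1.3-fold higher number from compound 1 to compound 2 (0.12 log units; within the scatter) and a 1.3-fold higher number from compound 1 to compound 3 (0.12 log units; within the scatter). Neither separates from the scatter, and this assay has so far given no sign of a response to the group at this place across these three compounds.

No step beyond the scatter is therefore expected, and the estimate is a 1.3-fold higher number from compound 1 to compound 4 (0.12 log units; within the scatter). For compound 4 the expected value is 0.04 ug/mL, with an estimated range of 0.02 ug/mL to 0.08 ug/mL.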

Compound 4, half-maximal inhibitory concentration: 0.13 ug/mL
Compound 4: the middle estimate sits 3.3-fold (0.51 log units) below what was measured; the whole stated range lies below it.
By their numbers in this assay, from the lowest: compounds 1, 2 and 3 (each within the scatter of the next); then compound 4.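

In this assay the group at this place does register: methyl in place of ethoxy gives a 4.3-fold higher number from compound 1 to compound 4 (0.64 log units; beyond the scatter) and so separates from the scatter, which the earlier replacements of ethoxy by fluoro and by iodo did not. Methyl also parts from both halogen compounds, with a 3.3-fold higher number from compound 2 to compound 4 (0.51 log units; beyond the scatter) and a 3.3-fold higher number from compound 3 to compound 4 (0.51 log units; beyond the scatter), so among the four compounds ethoxy, fluoro and iodo stay together and methyl alone stands apart, on the side of weaker inhibition. Nothing at hand accounts for this separation of methyl from the other three groups.

Going by these compounds, whether the step belongs to methyl alone or extends to ethyl, methoxy or an amine at this place remains open, as does whether a longer chain such as butoxy would fall with compound 1 or with compound 4. The compounds shown also leave open whether methyl in place of ethoxy would give a step of this size on a core other than the one shared here.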